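The source may report more compounds than this note shows. Statements on the series, on what has been measured and on what is new or still open speak of the compounds shown alone.

Three compounds were measured in a functional assay on MDA-MB-231 cells (Homo sapiens) for antiproliferative activity, read by CCK-8 assay, with a stated time of 72 h; on this read-out lower numbers stand for stronger inhibition and higher numbers for weaker inhibition:

Compound 1 `O=C(Nc1cccc(-c2oc3cc(-c4ccc(F)cc4)ccc3c(=O)c2O)c1)c1ccc(F)cc1`: 16000 nM
Compound 2 `COc1cccc(C(=O)Nc2cccc(-c3oc4cc(-c5ccc(F)cc5)ccc4c(=O)c3O)c2)c1`: 9160 nM
Compound 3 `COc1ccc(C(=O)Nc2cccc(-c3oc4cc(-c5ccc(F)cc5)ccc4c(=O)c3O)c2)c(F)c1`: 17600 nM

Compound 1 lies within the scatter of both others: the step of a 1.7-fold lower number from compound 1 to compound 2 (0.24 log units; within the scatter) and the step of a 1.1-fold higher number from compound 1 to compound 3 (0.04 log units; within the scatter) are each small, as is the step of a 1.9-fold higher number from compound 2 to compound 3 (0.28 log units; within the scatter). All three measured steps change only the aryl group on the carbonyl carbon of the amide, and none moves the number beyond the scatter. Compound 4 `CCCc1ccc(C(=O)Nc2cccc(-c3oc4cc(-c5ccc(F)cc5)ccc4c(=O)c3O)c2)cc1` changes the same group: propyl in place of fluoro on an aromatic carbon. Because the step of a 1.7-fold lower number from compound 1 to compound 2 (0.24 log units; within the scatter) and the step of a 1.1-fold higher number from compound 1 to compound 3 (0.04 log units; within the scatter) each stay within the scatter, the step of a 1.1-fold lower number from compound 1 to compound 4 (0.06 log units; within the scatter) is expected to stay within it as well. Compound 4 is therefore estimated at 14000 nM, with a range from 6000 nM to 33000 nM.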

Compound 4, half-maximal inhibitory concentration: 32200 nM
The estimate for compound 4 lay 2.3-fold (0.36 log units) below the measured number; the range from low to high includes it.
By their numbers in this assay, from the lowest: compounds 2, 1, 3 and 4 (each within the scatter of the next, the first and the last beyond it).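

In this assay, changing the aryl group on the amide carbonyl now produces a step beyond the scatter (modest in size), with 4-propylphenyl in place of 3-methoxyphenyl (a 3.5-fold higher number from compound 2 to compound 4 (0.55 log units; beyond the scatter)). Propyl in place of fluoro stays within the scatter (a 2.0-fold higher number from compound 1 to compound 4 (0.30 log units; within the scatter)), as does 4-propylphenyl in place of 2-fluoro-4-methoxyphenyl (a 1.8-fold higher number from compound 3 to compound 4 (0.26 log units; within the scatter)). Going by these compounds alone, nothing measured here accounts for the one larger step.

The compounds shown leave open how an amine, a carboxylic acid or a chain longer than propyl in place of fluoro would read in this assay.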